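This account rests on a few compounds, and the source may have more. Where it says the series, first, only, none or still open, it means among the compounds named here.

Of the compounds shown here, three have been measured in an ADME assay on MT4 cells (Homo sapiens) for cytotoxicity, read by MTT assay; a lower number here means that less compound is tolerated, a higher number that more compound is tolerated. Compound 1 `COc1cccc2c1c(C(=O)/C=C(\O)C(=O)O)cn2Cc1cccc(F)c1F` gives 17500 nM in this assay. Compound 2 `CCOC(=O)/C(O)=C/C(=O)c1cn(Cc2cccc(F)c2F)c2cccc(OC)c12` gives 21100 nM, and compound 3 `CCOC(=O)/C(O)=C/C(=O)c1cn(Cc2c(F)cccc2F)c2cccc(OC)c12` gives 63400 nM, the highest of the three numbers. The cores of compound 2 and compound 3 differ in one place: 2,6-difluorophenyl in place of 2,3-difluorophenyl on a saturated chain carbon bound to an aromatic nitrogen. That change gives a 3.0-fold higher number from compound 2 to compound 3 (0.48 log units; beyond the scatter). Compound 1 differs from compound 2 by hydrogen in place of ethyl on an oxygen next to a carbonyl group, and this change gives a 1.2-fold lower number from compound 2 to compound 1 (0.08 log units; within the scatter).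

Compound 4 `COc1cccc2c1c(C(=O)/C=C(\O)C(=O)O)cn2Cc1c(F)cccc1F` has not yet been measured in this assay. It differs from compound 3 by hydrogen in place of ethyl on an oxygen next to a carbonyl group, the same change as from compound 2 to compound 1, made at the same place. A step of similar size is expected here, a 1.2-fold lower number from compound 3 to compound 4 (0.06 log units; within the scatter). This expectation rests on a single earlier pair, which showed a 1.2-fold lower number from compound 2 to compound 1 (0.08 log units; within the scatter), so little movement is anticipated. Compound 4 is therefore estimated to give 55000 nM in this assay, with a likely range from 25000 nM to 120000 nM.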

Compound 4, half-maximal cytotoxic concentration: 44300 nM
Compound 4: the middle estimate sits 1.2-fold (0.09 log units) above what was measured, and the stated range covers the measured number.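

In this assay, hydrogen in place of ethyl on an oxygen next to a carbonyl group again leaves the number within the scatter, with a 1.4-fold lower number from compound 3 to compound 4 (0.16 log units; within the scatter), and the step matches the one on the other core: the same change on two cores in this assay, a 1.2-fold lower number (0.08 log units; within the scatter) from compound 2 to compound 1 and a 1.4-fold lower number (0.16 log units; within the scatter) from compound 3 to compound 4, 1.2-fold (0.07 log units) apart, within the scatter of two such steps. The exchange of 2,3-difluorophenyl for 2,6-difluorophenyl also carries over, this time with the carboxy group in place, giving a 2.5-fold higher number from compound 1 to compound 4 (0.40 log units; beyond the scatter), and its size holds as well: the same change on two cores in this assay, a 3.0-fold higher number (0.48 log units; beyond the scatter) from compound 2 to compound 3 and a 2.5-fold higher number (0.40 log units; beyond the scatter) from compound 1 to compound 4, 1.2-fold (0.07 log units) apart, within the scatter of two such steps. Together the four compounds show that each change behaves alike on the two cores tested, but each comparison rests on only two pairs, so this does not show that either step would carry to a core outside these four compounds or to any other assay.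

The compounds shown leave open whether a longer chain than ethyl on that oxygen, or an amine in place of the ethoxy group, would fit the same picture. They also leave open how a benzyl group without fluorine, or with chlorine in its place, would compare with the two difluorophenyl groups.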